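The source may report more compounds than this note shows. Statements on the series, on what has been measured and on what is new or still open speak of the compounds shown alone.

In an ADME assay on microsomes from liver (Homo sapiens) for metabolic stability, with a stated time of 10 min (a lower number here means that less of the compound is left, a higher number that more of the compound is left), compound 1 (`CC(=O)N1CCC(O)(C(=O)N2CC[C@](c3ccc(C(OCc4c(F)cccc4F)(C(F)(F)F)C(F)(F)F)cc3)(S(=O)(=O)c3ccc(F)cc3)C2)CC1`) gives 16% and compound 2 (`O=C(O)[C@H]1CC[C@H](C(=O)N2CC[C@](c3ccc(C(OCc4ccccc4OC(F)(F)F)(C(F)(F)F)C(F)(F)F)cc3)(S(=O)(=O)c3ccc(F)cc3)C2)CC1`) gives 93%. Compound 2 is the higher of the two numbers, by a gap beyond the usual scatter, but the pair differs in more than one place, so that gap does not isolate any single change. Compound 3 (`O=C(O)[C@H]1CC[C@H](C(=O)N2CC[C@](c3ccc(C(OCC4CCCC4)(C(F)(F)F)C(F)(F)F)cc3)(S(=O)(=O)c3ccc(F)cc3)C2)CC1`) has cyclopentyl in place of 2-(trifluoromethoxy)phenyl on a saturated chain carbon bound to an oxygen on a saturated carbon. Going by the values given here, no measured pair shows this change, so any expectation is loose. A moderate drop beyond the scatter is expected in this assay, an estimated a number 18 percentage points lower from compound 2 to compound 3 (beyond the scatter). The estimate for compound 3 is 75%, with an expected range of 45% to 96%.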

Compound 3, percent of the compound remaining: 73%
Estimate against measurement, compound 3: 2 percentage points above; the measured number falls inside the stated range.
By their numbers in this assay, from the lowest: compound 1; then compound 3; then compound 2.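

In this assay replacing 2-(trifluoromethoxy)phenyl with cyclopentyl at this position gives a number 20 percentage points lower from compound 2 to compound 3 (beyond the scatter) and this single change can be read on its own. An aromatic ring at this position is therefore not needed for most of the compound to remain, although the change does lower the number. Nothing at hand explains the step. The compounds shown leave open how a straight butyl chain or a cyclohexyl ring would compare at this position. On these data alone, whether the same step would appear without the carboxylic acid also stays open.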